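Swapping tert-butyl for isobutyl on the thiadiazole end

The source may report more compounds than this note shows. Statements on the series, on what has been measured and on what is new or still open speak of the compounds shown alone.

Compound 1 `Cc1cccc(OC2CCN(c3ccc(-n4ccnc4)nn3)CC2)c1` gives 251 nM.
Compound 2 `CC(C)(C)c1nnc(-c2ccc(N3CCC(Oc4ccccc4C(F)(F)F)CC3)nn2)s1` gives 710 nM.
Compound 3 `c1cn(-c2ccc(N3CCC(Oc4ccc5c(c4)CCC5)CC3)nn2)cn1` gives 62 nM.

These values come from an assay on microsomes from liver for inhibition of acyl-CoA desaturase 1 (Rattus norvegicus); on this read-out lower numbers stand for stronger inhibition and higher numbers for weaker inhibition. Compound 2 gives the highest number of the three, so it is the weakest inhibitor here; compound 1 is nearest to it and compound 3 furthest away. Compound 4 `CC(C)Cc1nnc(-c2ccc(N3CCC(Oc4ccccc4C(F)(F)F)CC3)nn2)s1` differs from compound 2 only by isobutyl in place of tert-butyl on an aromatic carbon. For the measured compounds named here, the single measured step, a 4.0-fold lower number from compound 1 to compound 3 (0.61 log units; beyond the scatter), changes the group on the oxygen at the other end of the molecule, so no measured step bears on this change. With nothing to suggest a direction, the expectation is for no step beyond the scatter: a 1.1-fold higher number from compound 2 to compound 4 (0.05 log units; within the scatter). Compound 4 is therefore estimated at 800 nM, likely between 300 nM and 2200 nM.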

Compound 4, half-maximal inhibitory concentration: 37 nM
The estimate for compound 4 lay 22-fold (1.33 log units) above the measured number; measured number outside the range, below it.
By their numbers in this assay, from the lowest: compounds 4 and 3 (each within the scatter of the next); then compound 1; then compound 2.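

In this assay, rearranging the same four carbons from tert-butyl to isobutyl on the thiadiazole gives a 19-fold lower number from compound 2 to compound 4 (1.28 log units; beyond the scatter), so this position responds strongly to the shape of the chain even though the counted atoms and hydrogen-bond features stay the same. For the compounds shown here, the only earlier step changed the group on the oxygen at the other end of the molecule, so this is the first view of how much the thiadiazole end can matter. Nothing measured here offers a reason for the size of this step.

On these data alone, whether an ethyl group, a longer chain such as n-pentyl, or a cyclopropyl ring would behave more like isobutyl or like tert-butyl remains open. Also open, as far as these compounds go, is whether isobutyl gives a similar step when the oxygen carries 2,3-dihydro-1H-inden-5-yl.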